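This account rests on a few compounds, and the source may have more. Where it says the series, first, only, none or still open, it means among the compounds named here.

Compound 1 `Cc1noc(NS(=O)(=O)c2ccc(NCc3ccccc3)cc2)c1C` gives 9800 nM in an assay on VSM-A10 cells for antagonist activity at Endothelin-1 receptor (Rattus norvegicus); a higher number here means a weaker inhibitor, a lower number a stronger inhibitor.
Compound 2 `Cc1noc(NS(=O)(=O)c2cccc3c(NCCCCCc4ccccc4)cccc23)c1C` gives 3050 nM in this assay.
Compound 3 `CN(C)c1cccc2c(S(=O)(=O)Nc3onc4c3CCCC4)cccc12` gives 153000 nM in this assay.

Among these three, compound 2 has the lowest number, and both gaps to it lie beyond the usual scatter: compound 1 sits clearly higher, and compound 3 higher still by a wide margin. Compound 2 is thus the strongest inhibitor of the three in this assay.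

Compound 4 `Cc1noc(NS(=O)(=O)c2cccc3c(NCc4ccccc4)cccc23)c1C` has not yet been measured. It keeps the core of compound 2 and differs in one place: phenyl in place of 4-phenylbutyl on a saturated chain carbon bound to a nitrogen on an aromatic ring. In plainer terms, the chain that links the aromatic nitrogen to the terminal ring is cut short, so that a benzyl group remains where a longer arm used to be.

For the measured compounds named here, no pair of measured compounds shows what this shortening does on this core. The nearest hint is compound 1, which carries a benzyl group on a smaller core and gives 9800 nM in this assay. A modest rise in the number, a small loss of inhibition, seems the more likely outcome, though a step within the scatter cannot be ruled out. Compound 4 is therefore expected to give about 6000 nM in this assay, in a range from 1500 nM to 25000 nM. That estimate corresponds to an expected step of a 2.0-fold higher number from compound 2 to compound 4 (0.29 log units; within the scatter).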

Compound 4, half-maximal inhibitory concentration: 590 nM
Beside the measured number, compound 4's estimate is 10-fold (1.01 log units) above it; the whole stated range lies above it.
By their numbers in this assay, from the lowest: compound 4; then compound 2; then compound 1; then compound 3.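

For the compounds shown here, compound 2 and compound 4 form the first pair here that differs in one place, and they show that the long arm on this nitrogen is not needed for inhibition on this core. Cutting 5-phenylpentyl back to benzyl keeps the terminal aromatic ring but shortens the link to it, and in this assay this gives a 5.2-fold lower number from compound 2 to compound 4 (0.71 log units; beyond the scatter), so between these two arm lengths the shorter one is the better inhibitor. No measurement here explains why the shorter arm gives the lower number.

Two arm lengths cannot show how the number changes along the series, so a 2-phenylethyl or 3-phenylpropyl arm might fall on a smooth trend between compound 4 and compound 2 or might break from one. From the compounds shown here alone, it also remains open whether the terminal ring itself matters, which a plain methyl or cyclohexylmethyl group on the nitrogen could test, and whether a methoxy group or a fluorine on that ring would shift the number further.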